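Ethyl to allyl on the ring nitrogen of compound 2

A few compounds are considered here, and "the series" means these few. Any claim that something is new, unique, unknown or untested is made for them only; others in the source may bear on it.

Measured so far:
compound 1 `Oc1nnc(Cc2cccc3ccccc23)c2ccccc12`: 4400 nM
compound 2 `CCn1nc(Cc2ccc(OC)c(OC)c2)c2ccccc2c1=O`: 5300 nM
compound 3 `CCn1nc(Cc2ccc(OC)cc2)c2ccccc2c1=O`: "not determined" (no result reported)

In a functional assay on aorta with Alpha-1D adrenergic receptor (Rattus norvegicus) as the target (on this read-out lower numbers stand for an effect already at smaller amounts and higher numbers for an effect only at larger amounts of compound), compound 1 gives 4400 nM and compound 2 gives 5300 nM; the two numbers lie within the scatter of each other, so neither can be called the more potent. For compound 3 the entry reads "not determined" (no result reported), so no number is available for it. Compound 4 `C=CCn1nc(Cc2ccc(OC)c(OC)c2)c2ccccc2c1=O` differs from compound 2 by one change: vinyl in place of methyl on a saturated chain carbon bound to an aromatic nitrogen. Within the data shown here, no step between measured compounds is available to show what such a change does. The change is small and adds no donor or acceptor, so the expected step from compound 2 to compound 4, a 1.2-fold lower number from compound 2 to compound 4 (0.07 log units; within the scatter), is one not beyond the scatter. Compound 4 is therefore estimated at 4500 nM, with a range from 1500 nM to 13000 nM.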

Compound 4, half-maximal effective concentration: 9800 nM
Beside the measured number, compound 4's estimate is 2.2-fold (0.34 log units) below it; the range from low to high includes it.
By their numbers in this assay, from the lowest: compounds 1, 2 and 4 (each within the scatter of the next, the first and the last beyond it).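

The first step read at this place in this assay is a 1.8-fold higher number from compound 2 to compound 4 (0.27 log units; within the scatter) for vinyl in place of methyl on a saturated chain carbon bound to an aromatic nitrogen. Compound 2 and compound 4 therefore cannot be told apart, and this place accepts the added double bond without a step beyond the scatter. Nothing at hand bears on this result.

The compounds shown leave open whether a longer chain, an amine or a carboxylic acid at this place would give a step beyond the scatter.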